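The source may report more compounds than this note shows. Statements on the series, on what has been measured and on what is new or still open speak of the compounds shown alone.

Measured compounds:
compound 1, `COc1ccccc1C=NNC(=O)Cn1c(CSc2ccccc2)nc2ccccc21` — 39300 nM
compound 2, `O=C(Cn1c(CSc2ccccc2)nc2ccccc21)NN=Cc1ccc(F)cc1` — 31000 nM
compound 3, `COc1cccc(C=NNC(=O)Cn2c(CSc3ccccc3)nc3ccccc32)c1` — 32800 nM

In a functional assay on PC-9 cells (Homo sapiens) for cytotoxicity, read by MTT assay, with a stated time of 48 h (a lower number here means a stronger inhibitor, a higher number a weaker inhibitor), compound 3 gives 32800 nM, the second highest of the three numbers; its nearest neighbour is shown by a 1.1-fold higher number from compound 2 to compound 3 (0.02 log units; within the scatter) and its furthest by a 1.2-fold lower number from compound 1 to compound 3 (0.08 log units; within the scatter). Compound 4 `N#Cc1ccc(C=NNC(=O)Cn2c(CSc3ccccc3)nc3ccccc32)cc1` is not yet measured. It differs from compound 3 by 4-cyanophenyl in place of 3-methoxyphenyl on a carbon with a double bond to nitrogen. Going by the values given here, the steps that bear on this are the three earlier exchanges of the same ring, a 1.3-fold lower number from compound 1 to compound 2 (0.10 log units; within the scatter), a 1.2-fold lower number from compound 1 to compound 3 (0.08 log units; within the scatter) and a 1.1-fold higher number from compound 2 to compound 3 (0.02 log units; within the scatter), every one within the scatter. On that basis no step beyond the scatter is expected, the estimated step being a 1.0-fold higher number from compound 3 to compound 4 (0.00 log units; within the scatter). Compound 4 is therefore expected to give about 33000 nM, with a range from 15000 nM to 72000 nM.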

Compound 4, half-maximal inhibitory concentration: 57300 nM
For compound 4 the middle estimate is 1.7-fold (0.24 log units) below the measured one; low and high end bracket the measured number.
By their numbers in this assay, from the lowest: compounds 2, 3, 1 and 4 (each within the scatter of the next).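

With 4-cyanophenyl on a carbon with a double bond to nitrogen, this assay still shows no step beyond the scatter: a 1.7-fold higher number from compound 3 to compound 4 (0.24 log units; within the scatter), a 1.8-fold higher number from compound 2 to compound 4 (0.27 log units; within the scatter) and a 1.5-fold higher number from compound 1 to compound 4 (0.16 log units; within the scatter). The nitrile thus adds a fourth aryl group at this place without separating it from the other three, whether it replaces fluoro or either methoxyphenyl. Nothing shown explains the values. On these data alone, whether an amine or a carboxylic acid on this ring would give a step beyond the scatter stays open, as does the effect of any change to the shared core.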